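Trimming the chain on the core nitrogen: propyl to ethyl

The compounds below may be only part of what the source reports. "The series", "measured", "known", "first", "only" and "open" are said of these compounds alone.

Measured compounds:
Compound 1, `CCC(CC)Cn1c(Cc2cc(OC)c(OC)c(OC)c2)nc2c(N)ncnc21`, gives 158000 nM.
Compound 2, `CC/C=C/Cn1c(Cc2cc(OC)c(OC)c(OC)c2)nc2c(N)ncnc21`, gives 46800 nM.
Compound 3, `CCCn1c(Cc2cc(OC)c(OC)c(OC)c2)nc2c(N)ncnc21`, gives 46800 nM.

These three share one core and differ only in the group on the aromatic nitrogen. In a functional assay on MCF7 cells (Homo sapiens) for antiproliferative activity (a higher number here means a weaker inhibitor, a lower number a stronger inhibitor), compound 3 stands level with compound 2, and the two together hold the lowest numbers of the three; compound 1 sits furthest away, with a 3.4-fold lower number from compound 1 to compound 3 (0.53 log units; beyond the scatter). Compound 4, `CCn1c(Cc2cc(OC)c(OC)c(OC)c2)nc2c(N)ncnc21`, has not yet been measured. It differs from compound 3 by hydrogen in place of methyl on a saturated chain carbon, two bonds along the chain from an aromatic nitrogen; read one bond further out, the change is propyl to ethyl.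

Within the data shown here, two measured steps bear on this. Going from the branched pentan-3-yl to propyl gave a 3.4-fold lower number from compound 1 to compound 3 (0.53 log units; beyond the scatter), and swapping but-1-en-1-yl for ethyl on that carbon gave no change at the digits printed from compound 2 to compound 3 (within the scatter). So a shorter group on this nitrogen was once helpful and once neutral. Taking one more carbon away is therefore expected to give at most a small shift, close to the scatter, with the direction uncertain but leaning lower: the estimate for compound 4 is 35000 nM, within 15000 nM to 90000 nM, a step of a 1.3-fold lower number from compound 3 to compound 4 (0.13 log units; within the scatter).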

Compound 4, half-maximal inhibitory concentration: 79400 nM
For compound 4 the middle estimate is 2.3-fold (0.36 log units) below the measured one; the measured number falls inside the stated range.
By their numbers in this assay, from the lowest: compounds 2, 3, 4 and 1 (each within the scatter of the next, the first and the last beyond it).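

In this assay, trimming propyl to ethyl on the aromatic nitrogen gives a 1.7-fold higher number from compound 3 to compound 4 (0.23 log units; within the scatter), so removing this one carbon leaves a difference too small to separate from ordinary repeat-to-repeat variation. The comparisons with the two other groups, a 1.7-fold higher number from compound 2 to compound 4 (0.23 log units; within the scatter) and a 2.0-fold lower number from compound 1 to compound 4 (0.30 log units; within the scatter), also stay within the scatter, which means that compound 4 cannot be told apart from any of the three earlier compounds, even though compound 1 and compound 3 do differ beyond the scatter, and chain size therefore gives no clean stepwise trend across these four compounds. No supporting measurement is available to explain these numbers.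

From the compounds shown here alone, it remains open whether a hydroxyl-bearing chain, an amine, a carboxylic acid or a much longer chain on this nitrogen would give a number clearly apart from this group of values. The compounds shown also leave open whether a change elsewhere on the shared core, such as replacing a methoxy group on the trimethoxyphenyl part with a hydroxyl, would matter more than any change to this chain.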